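Working notes: chloro for fluoro, compound 4 expected

The compounds below may be only part of what the source reports. "The series", "measured", "known", "first", "only" and "open" are said of these compounds alone.

Measured in a functional assay on NCI-H1975 cells (Homo sapiens) for inhibition, read by MTT assay, with a stated time of 72 h; a lower number here means a stronger inhibitor, a higher number a weaker inhibitor:
compound 1 `O=C(CSc1nc(Nc2ccccc2)c2ccccc2n1)Nc1cccc(F)c1` gives 6790 nM
compound 2 `O=C(CSc1nc(Nc2ccccc2)c2ccccc2n1)Nc1cccc(Cl)c1` gives 8460 nM
compound 3 `C=CC(=O)Nc1cccc(NC(=O)CSc2nc(Nc3cccc(F)c3)c3ccccc3n2)c1` gives 2030 nM

Compound 1 and compound 2 differ only in one place, (chloro in place of fluoro on an aromatic carbon). The step is a 1.2-fold higher number from compound 1 to compound 2 (0.10 log units; within the scatter), so the two numbers are not distinguished in this assay.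

Compound 3 carries a different core from compound 1; the difference between the two cores is not broken down here. In this assay compound 3 gives the lowest of the three numbers, with its steps to compound 1 and compound 2 both beyond the scatter.

Compound 4 `C=CC(=O)Nc1cccc(NC(=O)CSc2nc(Nc3cccc(Cl)c3)c3ccccc3n2)c1` has not been measured. It differs from compound 3 by chloro in place of fluoro on an aromatic carbon, the same change, at the same place, as from compound 1 to compound 2; among the compounds here the change occurs two times in all.

The step of a 1.2-fold higher number from compound 3 to compound 4 (0.07 log units; within the scatter) is expected to be small because a 1.2-fold higher number from compound 1 to compound 2 (0.10 log units; within the scatter) stayed within the scatter. Compound 4 is therefore estimated at 2400 nM in this assay, expected between 1200 nM and 5000 nM.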

Compound 4, half-maximal inhibitory concentration: 9460 nM
Estimate against measurement, compound 4: 3.9-fold (0.60 log units) below; measured number above the stated range.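

In this assay, chloro in place of fluoro gives a 4.7-fold higher number from compound 3 to compound 4 (0.67 log units; beyond the scatter), so the change is visible on the core of compound 3, whereas on the core of compound 1 it stayed within the scatter. The size of this step therefore does not carry over from one core to the other in this series: the same change on two cores in this assay, a 1.2-fold higher number (0.10 log units; within the scatter) from compound 1 to compound 2 and a 4.7-fold higher number (0.67 log units; beyond the scatter) from compound 3 to compound 4, 3.7-fold (0.57 log units) apart, beyond the scatter of two such steps

This rests on a single pair for each core, so it shows that the step depends on the core here, but not which feature of the core is responsible or how the change would behave on any further core.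

Going by these compounds, it remains open whether the higher number of compound 4 is particular to chloro, which a bromo or a methyl in place of the chloro on the same core would test. Also open, on these data alone, is whether the step persists when a propanamide replaces the acrylamide of compound 3 and compound 4.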